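Lengthening the Chain on the Core Nitrogen

The compounds below may be only part of what the source reports. "The series", "measured", "known", "first", "only" and "open" are said of these compounds alone.

Compound 3 `CCn1cnc(N)c2ncnc1-2` sits at the edge of what an assay on isolated protein (adrenal medulla) for inhibition of Dopamine beta-hydroxylase (Bos taurus) (on this read-out higher numbers stand for weaker inhibition and lower numbers for stronger inhibition), reports: in this assay compound 3 gives > 200 ug/mL, which is a limit of the assay and not a number (the limit of > 200 ug/mL in this assay, at which 1 of the 3 values shown sits). Compound 4 `CC(C)CCn1cnc(N)c2ncnc1-2` differs from compound 3 by isopropyl in place of hydrogen on a saturated chain carbon, two bonds along the chain from an aromatic nitrogen. Only one measured step exists among the compounds shown, a 100-fold higher number from compound 1 to compound 2 (2.00 log units; beyond the scatter), in which compound 1 `Nc1ncn(Cc2ccccc2)c2ncnc1-2` gives 2 ug/mL and compound 2 `Nc1ncn(Cc2ccccc2[N+](=O)[O-])c2ncnc1-2` gives 200 ug/mL. Among the measured compounds shown here, that step concerns a nitro group on an aromatic carbon and does not bear on a change at a saturated chain carbon, so no measured step speaks directly to the move from compound 3 to compound 4. Side by side, compound 1 gives the lower number while compound 3 stands at its limit, which hints that the chain carried on the core nitrogen matters. The step of an at least 2.0-fold lower number from compound 3 to compound 4 (0.30 log units; that floor lies within the scatter) is therefore expected to run toward a lower number, with wide uncertainty. Compound 4 is expected to give 100 ug/mL, within a range from 20 ug/mL to 250 ug/mL.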

Compound 4, half-maximal inhibitory concentration: 200 ug/mL
Beside the measured number, compound 4's estimate is 2.0-fold (0.30 log units) below it; measured number inside the range.
By their numbers in this assay, from the lowest: compound 1; then compounds 2 and 4 (each within the scatter of the next).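

Isopropyl in place of hydrogen on a saturated chain carbon, two bonds along the chain from an aromatic nitrogen, leads to a number no higher from compound 3 to compound 4 (the limit leaves the size open). Compound 3 stands at a limit of the assay and not at a number, so the size of this step cannot be read: the limit of > 200 ug/mL in this assay, at which 1 of the 4 values shown sits. What is new is a readable number for a chain without a ring at this position: where compound 3 carries ethyl, compound 4 carries isopentyl, and in this assay compound 4 gives 200 ug/mL.

The compounds shown leave open whether the branching of the isopropyl matters or only the extra chain length, which a straight propyl group in the same place would address. They also leave open how a longer chain, an amine or a carboxylic acid at this carbon would read in this assay.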